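From Phenylethenyl to Piperidinylmethyl: an Expected Whole-Animal Response

This account rests on a few compounds, and the source may have more. Where it says the series, first, only, none or still open, it means among the compounds named here.

Compound 1, `Nc1nc(O)c2c(n1)n(C1OC(CO)[C@@H](O)[C@H]1O)c(=O)n2C/C=C/c1ccccc1`: 5%
Compound 2, `CCCn1c(=O)n(C2CCC(COC(C)=O)O2)c2nc(NC(C)=O)nc(O)c21`: 11%
Compound 3, `C=CCn1c(=O)n([C@@H]2O[C@H](CO)[C@H]3OC(CCC)(CCC)O[C@H]32)c2nc(N)nc(O)c21`: 38%

In a functional assay on the whole organism with Mus musculus as the target (a higher number here means a larger maximal response, a lower number a smaller maximal response), compound 1 gives the lowest of the three values. The value of compound 2 lies within the usual scatter of that of compound 1, so no order can be read between them. Compound 3 lies beyond the scatter, higher than compound 1. Compound 4, `Nc1nc(O)c2c(n1)n(C1OC(CO)[C@@H](O)[C@H]1O)c(=O)n2CCN1CCCCC1`, differs from compound 1 as follows: (piperidin-1-yl)methyl in place of 2-phenylethenyl on a saturated chain carbon bound to an aromatic nitrogen. Going by the values given here, no measured pair in this set reproduces this change, so nothing in the numbers shows its size. The step of a number 9 percentage points higher from compound 1 to compound 4 (within the scatter) is expected to be small, rising slightly if at all, or none beyond the scatter. Compound 4 is estimated at 14%, with a range from 2% to 40%.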

Compound 4, largest response reached (reported as maximal response), in percent of the reference or control that the assay uses: 0%
Compound 4: middle estimate off by 14 percentage points, on the high side; measured number outside the range, below it.
By their numbers in this assay, from the lowest: compounds 4, 1 and 2 (each within the scatter of the next, the first and the last beyond it); then compound 3.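

In this assay, putting (piperidin-1-yl)methyl in place of 2-phenylethenyl on a saturated chain carbon bound to an aromatic nitrogen gives a number 5 percentage points lower from compound 1 to compound 4 (within the scatter), so the two compounds cannot be ordered. The position thus accepts a non-aromatic ring carrying a nitrogen instead of an aromatic carbon ring and a double bond, with no step beyond the scatter. Nothing at hand offers a reason for this result. Left open is whether a primary amine or a carboxylic acid on the same chain would move the response beyond the scatter of compound 1.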